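This account rests on a few compounds, and the source may have more. Where it says the series, first, only, none or still open, it means among the compounds named here.

Measured so far:
- compound 1, `O=C(NCc1ccc(N2CCC(c3ccc(OC(F)(F)F)cc3)CC2)cc1)c1cc([N+](=O)[O-])cc([N+](=O)[O-])c1`: 3260 ng.h/mL
- compound 2, `O=C(NCc1ccc(N2CCN(c3ccc(F)cc3)CC2)cc1)c1cc([N+](=O)[O-])cc([N+](=O)[O-])c1`: 219 ng.h/mL

Compound 1 stands highest of the two numbers in an ADME assay on the whole organism for pharmacokinetics, with Mus musculus as the target, at a dose of 50 mg/kg by the oral route; a higher number here means more compound in the circulation at the dose given, a lower number less compound in the circulation. Its nearest neighbour is compound 2, whose value lies well below it, a gap that the assay's usual scatter does not account for. Within the data shown here, no single-point step between these two measured compounds is available, so their two numbers can only be read side by side.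

Compound 3, `O=C(NCc1ccc(N2CCC(C(F)(F)F)CC2)cc1)c1cc([N+](=O)[O-])cc([N+](=O)[O-])c1`, has not yet been measured in this assay. It is reached from compound 1 by one change: trifluoromethyl in place of 4-(trifluoromethoxy)phenyl on a saturated ring carbon. The shared core, the amide and the ring bearing the nitro groups, is kept; what changes is the group on the saturated ring carbon.

Among the measured compounds shown here, no step of this kind between measured compounds is known here, so the size and direction must be guessed from compound 1 alone. A step of moderate size in either direction would not be surprising. The expected change from compound 1 to compound 3 is a 2.2-fold lower number from compound 1 to compound 3 (0.34 log units; beyond the scatter). For compound 3 the estimated value in this assay is 1500 ng.h/mL, with a likely range from 400 ng.h/mL to 5000 ng.h/mL.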

Compound 3, area under the concentration-time curve: 5610 ng.h/mL
Compound 3: the middle estimate sits 3.7-fold (0.57 log units) below what was measured, outside the stated range (above it).
By their numbers in this assay, from the lowest: compound 2; then compounds 1 and 3 (each within the scatter of the next).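

Swapping the 4-(trifluoromethoxy)phenyl on the saturated ring carbon for trifluoromethyl gives, in this assay, a 1.7-fold higher number from compound 1 to compound 3 (0.24 log units; within the scatter), and this step lies within the usual scatter, so the two compounds cannot be told apart on this read-out. This position therefore tolerates a large change in the group it carries: a group of 11 heavy atoms with a six-membered aromatic ring gives way to one of 4 heavy atoms with no ring, and the amount of compound in the circulation stays at the same level. Nothing measured here accounts for why the number stays at this level after so much of the group is removed.

The compounds shown leave open how other groups on this saturated ring carbon would read, such as a methyl, a hydroxyl, an amine or a carboxylic acid. They also leave open whether a plain phenyl at this place would sit at the same level, or whether the fluorine atoms that both groups carry play any part in it.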